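The compounds below may be only part of what the source reports. "The series", "measured", "known", "first", "only" and "open" are said of these compounds alone.

Working notes on the series. Compound 1 `O=C(/C=C/c1ccccc1Br)NNC(=O)c1ccc2c(c1)OCCO2` and compound 2 `O=C(/C=C/c1ccccc1Cl)NNC(=O)c1ccc2c(c1)OCCO2` share one core and differ only in the halogen on the phenyl ring. In an ADME assay on cells (Macrophage) for cytotoxicity, read by MTT assay, with a stated time of 24 h (a lower number here means that less compound is tolerated, a higher number that more compound is tolerated), compound 1 gives 315000 nM, the higher of the two numbers available, and compound 2 gives 285000 nM. Among the compounds with values here, the only step measured so far, a 1.1-fold lower number from compound 1 to compound 2 (0.04 log units; within the scatter), came with chloro in place of bromo on an aromatic carbon and does not separate the two compounds beyond the scatter.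

Compound 3 `O=C(/C=C/c1ccccc1F)NNC(=O)c1ccc2c(c1)OCCO2` differs from compound 1 by fluoro in place of bromo on an aromatic carbon. Within the data shown here, the one measured step that bears on this exchange is the step from compound 1 to compound 2, which was within the scatter, so for compound 3 no step beyond the scatter is expected in this assay in either direction. Compound 3 is therefore estimated at 300000 nM, with a range from 200000 nM to 450000 nM, which corresponds to an expected step of a 1.1-fold lower number from compound 1 to compound 3 (0.02 log units; within the scatter).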

Compound 3, half-maximal cytotoxic concentration: 302000 nM
Estimate against measurement, compound 3: 1.0-fold (0.00 log units) below; measured number inside the range.
By their numbers in this assay, from the lowest: compounds 2, 3 and 1 (each within the scatter of the next).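

Fluoro now joins bromo and chloro at this place, on an aromatic carbon ortho to a large group, and this assay shows a 1.0-fold lower number from compound 1 to compound 3 (0.02 log units; within the scatter) and also a 1.1-fold higher number from compound 2 to compound 3 (0.03 log units; within the scatter) as its new steps. The earlier pair covered only the exchange of chloro for bromo, whereas all three halogens now stand within the scatter of one another, and none of the three compounds goes against this. No measurement at hand gives a reason for this flat reading.

On these data alone, it remains open whether a group other than a halogen at this place, such as an amine, a carboxylic acid or a longer chain, would leave the number within the scatter. As far as these compounds go, it also remains open whether the same flat reading would hold for a halogen on another carbon of the phenyl ring.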